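Ester series: methoxy to isobutoxy

This account rests on a few compounds, and the source may have more. Where it says the series, first, only, none or still open, it means among the compounds named here.

In a functional assay on the whole organism (strain Sprague-Dawley) for inhibition, with Rattus norvegicus as the target, with a stated time of 10 min (on this read-out lower numbers stand for an effect already at smaller amounts and higher numbers for an effect only at larger amounts of compound), compound 3 (`CCOC(=O)c1cnc(-c2ccccc2OC)[nH]c1=O`) gives 10 mg/kg, within the scatter of compound 2 (`CCOC(=O)c1cnc(-c2ccccc2O)[nH]c1=O`) at 5 mg/kg and clearly higher than compound 1 (`CC(C)COc1ccccc1-c1ncc(C(=O)O)c(=O)[nH]1`) at 0.5 mg/kg. Compound 4 (`CCOC(=O)c1cnc(-c2ccccc2OCC(C)C)[nH]c1=O`) differs from compound 3 by isopropyl in place of hydrogen on a saturated chain carbon bound to an oxygen on an aromatic ring, or methoxy to isobutoxy. Among the measured compounds shown here, the only measured step on that oxygen is a 2.0-fold higher number from compound 2 to compound 3 (0.30 log units; within the scatter), which gives little guidance. Compound 1 at 0.5 mg/kg carries isobutoxy but is an acid, not an ester, so it supports only a moderate expectation. The expected step is a 3.3-fold lower number from compound 3 to compound 4 (0.52 log units; beyond the scatter), toward a lower number. Compound 4 is estimated at 3 mg/kg, with an expected range of 0.7 mg/kg to 12 mg/kg.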

Compound 4, dose for 50% inhibition: 3 mg/kg
Compound 4: the middle estimate sits on the measured number at the digits printed; low and high end bracket the measured number.
By their numbers in this assay, from the lowest: compound 1; then compounds 4, 2 and 3 (each within the scatter of the next, the first and the last beyond it).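

In this assay, among the compounds shown here, the change from methoxy to isobutoxy gives a 3.3-fold lower number from compound 3 to compound 4 (0.52 log units; beyond the scatter) and is the first step on this oxygen that lies beyond the scatter, whereas a 1.7-fold lower number from compound 2 to compound 4 (0.22 log units; within the scatter) does not separate the two compounds. With isobutoxy kept in place, ethyl on the acid oxygen gives a 6.0-fold higher number from compound 1 to compound 4 (0.78 log units; beyond the scatter) and so separates the ester from the acid. No measurement on hand explains either step.

Open, going by these compounds, is whether a longer chain on this oxygen continues the step from methoxy. Also open, on these data alone, is how a carboxylic acid behaves with methoxy on that oxygen.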